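The source may hold more compounds than are shown below. What is called first, only, known or untested is meant among the compounds shown, and "the series" means these compounds.

Within the data shown here, in a functional assay on MIA PaCa-2 cells (Homo sapiens) for antiproliferative activity (a higher number here means that more compound is needed for the effect, a lower number that less compound is needed), compound 2 `CCCNC(=O)c1cccc2c1cc(C)n2-c1nc2c(c(NCc3ccccc3)n1)CCCC2` gives 608 nM and so has the lower of the two numbers measured so far, though compound 1 `CC#CCNC(=O)c1cccc2c1cc(C)n2-c1nc2c(c(NCc3ccccc3)n1)CCCC2`, at 723 nM, lies within the scatter of it: the step of a 1.2-fold lower number from compound 1 to compound 2 (0.08 log units; within the scatter). Compound 3 `CCCC#CC(=O)Nc1cccc2c1cc(C)n2-c1nc2c(c(NCc3ccccc3)n1)CCCC2` is the next compound to be measured in this assay. It differs from compound 2 at the amide side of the shared core: a group of 8 heavy atoms (6 carbon, 1 nitrogen, 1 oxygen; no ring) in place of a group of 6 heavy atoms (4 carbon, 1 nitrogen, 1 oxygen; no ring), on an aromatic carbon. Among the measured compounds shown here, the only step measured so far, from compound 1 to compound 2, exchanged ethyl for prop-1-yn-1-yl on the amide nitrogen and stayed within the scatter; it says nothing about the present change, which rebuilds the whole group and brings a triple bond into it. Without a step of this kind in hand, the expectation for compound 3 is a step of a 1.5-fold higher number from compound 2 to compound 3 (0.17 log units; within the scatter) with a wide range. Compound 3 is therefore estimated at 900 nM, between 250 nM and 3500 nM.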

Compound 3, half-maximal effective concentration: 1570 nM
Estimate against measurement, compound 3: 1.7-fold (0.24 log units) below; the measured number falls inside the stated range.
By their numbers in this assay, from the lowest: compounds 2 and 1 (each within the scatter of the next); then compound 3.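

In this assay the rebuilt group shows a measurable effect at this aromatic carbon, with a 2.6-fold higher number from compound 2 to compound 3 (0.41 log units; beyond the scatter) and also a 2.2-fold higher number from compound 1 to compound 3 (0.34 log units; beyond the scatter) whereas the earlier exchange on the amide nitrogen stayed within the scatter. A triple bond alone does not set compound 3 apart, since compound 1 also carries one and remains within the scatter of compound 2. No measurement shown here accounts for the rise.

The new group differs from propylcarbamoyl in more than one feature, and the compounds shown cannot separate the contribution of its extra atoms from that of its triple bond or of the way it is joined to the aromatic carbon. As far as these compounds go, how an amine, a carboxylic acid or a fully saturated chain would read on the same aromatic carbon also remains open.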